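The source may report more compounds than this note shows. Statements on the series, on what has been measured and on what is new or still open speak of the compounds shown alone.

Of the compounds shown here, three have so far been measured in a functional assay on BEAS-2B cells (Homo sapiens) for inhibition, read by MTT assay, with a stated time of 72 h; a lower number here means a stronger inhibitor, a higher number a weaker inhibitor. Compound 1 `C=C(c1ccc(Cl)c(Cl)c1Cl)C1COC(C)(C)OO1` gives 10200 nM, and compound 2 `C=C(c1cc(Cl)cc(Cl)c1OCc1ccccc1)C1COC(C)(C)OO1` gives 25500 nM. Compound 3 `C=C(c1ccc(F)c(F)c1)C1COC2(CCCCC2)OO1` gives 61200 nM, the highest of the three numbers, which makes it the weakest inhibitor of the set, and its distance from each of the other two lies beyond the scatter.

The next compound, compound 4 `C=C(c1ccc(OC)c(F)c1)C1COC2(CCCCC2)OO1`, has not yet been measured. It differs from compound 3 in one place: methoxy in place of fluoro on an aromatic carbon. Methoxy stands in place of fluoro on an aromatic carbon, ortho to a fluoro group and para to a large group. Among the measured compounds shown here, no two measured compounds differ in one place only, and none of them carries a methoxy group, so the data offer no direct precedent for this change.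

The expectation in this assay is therefore cautious: a small move towards a lower number, staying within the scatter. It rests only on compound 3, at 61200 nM, standing above both other measured compounds. The expected change is a 1.4-fold lower number from compound 3 to compound 4 (0.13 log units; within the scatter). For compound 4 the estimated value is 45000 nM, with an expected range from 18000 nM to 110000 nM.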

Compound 4, half-maximal inhibitory concentration: 37700 nM
For compound 4 the middle estimate is 1.2-fold (0.08 log units) above the measured one; the measured number falls inside the stated range.
By their numbers in this assay, from the lowest: compound 1; then compounds 2, 4 and 3 (each within the scatter of the next, the first and the last beyond it).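

In this assay, among the compounds shown here, replacing fluoro with methoxy on an aromatic carbon, ortho to a fluoro group and para to a large group, gives a 1.6-fold lower number from compound 3 to compound 4 (0.21 log units; within the scatter) and so provides the first reading of a change made in one place only. Methoxy brings 2 heavy atoms where fluoro had 1, and it adds 1 hydrogen-bond acceptor, yet the number stays within the scatter, so in this pair the position accepts the larger group with no measurable shift in either direction. Nothing given here offers a measured reason for how this pair behaves, and the result can be taken only as a description of what the two numbers show.

The compounds shown leave open whether this position would stay as undemanding with a different kind of group, such as an amine, a carboxylic acid or a longer chain like butoxy. They also leave open whether methoxy in place of fluoro would give a similar step in a compound that has a different set of groups on the aromatic ring or a different group on the rest of the shared core.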